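Swapping the Aryl Substituent on the Piperazine: Compound 3

The compounds below may be only part of what the source reports. "The series", "measured", "known", "first", "only" and "open" are said of these compounds alone.

Going by the values given here, compound 2 `Nc1scc(CN2CCN(c3ccc([N+](=O)[O-])cc3)CC2)c1C(=O)c1ccc(Cl)cc1` gives -8.3% in a functional assay on CHO cells with adenosine receptor A1 (Homo sapiens) as the target, read by cAMP accumulation and immunoassay, with a stated time of 6 min, tested at 1 uM (a lower number here means a stronger effect, a higher number a weaker effect of the compound at the concentration tested), the higher of the two numbers so far; compound 1 `Nc1scc(CN2CCN(c3cc(Cl)cc(Cl)c3)CC2)c1C(=O)c1ccc(Cl)cc1` gives -69%. Compound 3 `Nc1scc(CN2CCN(c3ccc(OC(F)(F)F)cc3)CC2)c1C(=O)c1ccc(Cl)cc1` differs from compound 2 by trifluoromethoxy in place of nitro on an aromatic carbon. Among the compounds with values here, the only step that bears on this also changed the aryl group on the ring amine nitrogen, a number 60.7 percentage points higher from compound 1 to compound 2 (beyond the scatter), so a shift of similar size is possible in either direction. Compound 3 is therefore expected to lie somewhere between the two measured values, with an estimated step of a number 26.7 percentage points lower from compound 2 to compound 3 (beyond the scatter) and a value of about -35%, ranging from -75% to 5%.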

Compound 3, a percentage reported as activity, at one concentration (the size of the read-out at that concentration, not a potency): -51%
Compound 3: the middle estimate sits 16 percentage points above what was measured, within the range that was stated.
By their numbers in this assay, from the lowest: compound 1; then compound 3; then compound 2.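

Changing only the group on the aromatic carbon para to a large group gives a number 42.7 percentage points lower from compound 2 to compound 3 (beyond the scatter) in this assay, so this one position can shift the result strongly with the rest of the molecule unchanged. Even so, 4-(trifluoromethoxy)phenyl in place of 3,5-dichlorophenyl gives a number 18 percentage points higher from compound 1 to compound 3 (beyond the scatter) and does not fully match it. No measurement available here explains why these groups differ. Open, from the compounds shown here alone, is what an amine, a carboxylic acid or a methoxy group on this same carbon would give, and how a phenyl ring carrying a single chlorine would compare.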